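Moving a methoxy group on a benzoyl substituent

The source may report more compounds than this note shows. Statements on the series, on what has been measured and on what is new or still open speak of the compounds shown alone.

Of the compounds shown here, three share one core and have been tested in a functional assay on HepG2 cells (Homo sapiens) for inhibition, read by MTT assay, with a stated time of 24 h; on this read-out higher numbers stand for weaker inhibition of growth and lower numbers for stronger inhibition of growth. Compound 1 `COc1cccc(C(=O)n2c(-c3cn(C)c4ccccc34)nc3ccccc32)c1` gives 13600 nM. Compound 2 `COc1ccc(C(=O)n2c(-c3cn(C)c4ccccc34)nc3ccccc32)cc1` gives 15200 nM. Compound 3 `COc1cccc(C(=O)n2c(-c3cn(C)c4ccc(OC)cc34)nc3ccccc32)c1` gives 11700 nM. Compound 3 differs from compound 1 by methoxy in place of hydrogen on an aromatic carbon. The change from compound 1 to compound 2 is 4-methoxyphenyl in place of 3-methoxyphenyl on a carbonyl carbon, and it gave a 1.1-fold higher number from compound 1 to compound 2 (0.05 log units; within the scatter). Among the measured compounds shown here, compound 4 `COc1ccc(C(=O)n2c(-c3cn(C)c4ccc(OC)cc34)nc3ccccc32)cc1` has not yet been measured; it differs from compound 3 by 4-methoxyphenyl in place of 3-methoxyphenyl on a carbonyl carbon, which is the same change as the one from compound 1 to compound 2, on the same place. Because the step of a 1.1-fold higher number from compound 1 to compound 2 (0.05 log units; within the scatter) stayed within the scatter, the expected step from compound 3 to compound 4 is a 1.1-fold higher number from compound 3 to compound 4 (0.05 log units; within the scatter), of a similar size. On that basis compound 4 is estimated at 13000 nM, between 7000 nM and 25000 nM.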

Compound 4, concentration for 50% growth inhibition: 12800 nM
Estimate against measurement, compound 4: 1.0-fold (0.01 log units) above; measured number inside the range.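

Moving the methoxy from 3-methoxyphenyl to 4-methoxyphenyl on the carbonyl carbon gives a 1.1-fold higher number from compound 3 to compound 4 (0.04 log units; within the scatter) in this assay, which repeats the earlier step on the other core: the same change on two cores in this assay, a 1.1-fold higher number (0.05 log units; within the scatter) from compound 1 to compound 2 and a 1.1-fold higher number (0.04 log units; within the scatter) from compound 3 to compound 4, 1.0-fold (0.01 log units) apart, within the scatter of two such steps. Putting methoxy in place of hydrogen on an aromatic carbon gives a 1.2-fold lower number from compound 2 to compound 4 (0.07 log units; within the scatter), and this also repeats: the same change on two cores in this assay, a 1.2-fold lower number (0.07 log units; within the scatter) from compound 1 to compound 3 and a 1.2-fold lower number (0.07 log units; within the scatter) from compound 2 to compound 4, 1.0-fold (0.01 log units) apart, within the scatter of two such steps. Both changes therefore look the same on both cores, but every step is too small to tell from the scatter, so this does not show that either change alters growth inhibition, nor that a larger step would carry across cores in the same way.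

Still open, on these data alone, is whether an amine or a carboxylic acid in place of the methoxy would give a step beyond the scatter.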